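Shifting Two Chlorines Around One Phenyl Ring

A few compounds are considered here, and "the series" means these few. Any claim that something is new, unique, unknown or untested is made for them only; others in the source may bear on it.

Measured so far:
compound 1, `O=C(/C=C/c1ccc(Oc2ncnc3ccc(Cl)cc23)cc1)/C=C/c1c(Cl)cccc1Cl`: 6770 nM
compound 2, `O=C(/C=C/c1ccc(Oc2ncnc3ccc(Cl)cc23)cc1)/C=C/c1ccc(Cl)c(Cl)c1`: 16900 nM

Both were tested in a functional assay on MGC-803 cells (Homo sapiens) for inhibition, read by MTT assay, with a stated time of 72 h; a lower number here means a stronger inhibitor, a higher number a weaker inhibitor. Among the measured compounds shown here, compound 2 holds the higher of the two numbers; the only measured step, a 2.5-fold higher number from compound 1 to compound 2 (0.40 log units; beyond the scatter), separates it from compound 1. Compound 3, `O=C(/C=C/c1ccc(Oc2ncnc3ccc(Cl)cc23)cc1)/C=C/c1cccc(Cl)c1Cl`, differs from compound 2 by 2,3-dichlorophenyl in place of 3,4-dichlorophenyl on a double-bonded chain carbon bound to a double-bonded chain carbon. For the measured compounds named here, that one step is the only guide, and it shows that moving the chlorines changed the number modestly. Compound 3 is therefore expected to give a somewhat lower number than compound 2, a step of a 1.7-fold lower number from compound 2 to compound 3 (0.23 log units; within the scatter) in this assay. The estimate for compound 3 is 10000 nM, with a range from 4000 nM to 25000 nM.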

Compound 3, half-maximal inhibitory concentration: 7300 nM
Compound 3: middle estimate off by 1.4-fold (0.14 log units), on the high side, and the stated range covers the measured number.
By their numbers in this assay, from the lowest: compounds 1 and 3 (each within the scatter of the next); then compound 2.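

Swapping 3,4-dichlorophenyl for 2,3-dichlorophenyl in this assay gives a 2.3-fold lower number from compound 2 to compound 3 (0.36 log units; beyond the scatter) so the placing of the two chlorines matters at this position. Set against 2,6-dichlorophenyl, the same group gives a 1.1-fold higher number from compound 1 to compound 3 (0.03 log units; within the scatter) so those two arrangements cannot be told apart here, and only 3,4-dichlorophenyl stands apart among these three. Nothing available explains why the numbers differ. The compounds shown leave open how this ring would read with a single chlorine. They also leave open what an amine or a methoxy group would do in place of the chlorines.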